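The source may hold more compounds than are shown below. What is called first, only, known or untested is meant among the compounds shown, and "the series" means these compounds.

Measured compounds:
- compound 1, `N=C(N)NCCC[C@H](NC(=O)CN(c1nc(Cl)nc2[nH]cnc12)C1CC1)C(=O)OCc1ccccc1`: 10.2%
- compound 2, `O=C(OCc1ccccc1)[C@@H]1CCCN1C(=O)CN(c1nc(Cl)nc2[nH]cnc12)C1CC1`: 38.4%
- compound 3, `C[C@H](NC(=O)CN(c1nc(Cl)nc2[nH]cnc12)C1CC1)C(=O)O`: 28.4%

All three compounds share the same core and were tested in a functional assay on the whole organism (Tail, strain ICR) with Mus musculus as the target, in the tail flick test, with a stated time of 120 min, at a dose of 25 umol/kg by the oral route; a lower number here means a weaker effect, a higher number a stronger effect of the compound at the dose given. On these numbers compound 1 stands lowest of the three: its nearest neighbour is compound 3, whose value lies higher by more than the usual scatter, and compound 2 lies higher still, also beyond the scatter. Among the measured compounds shown here, no pair of these measured compounds differs in only one place, so no single-change step has been measured, and nothing can be said about what any one change alone does.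

Compound 4, `CC[C@H](C)[C@H](NC(=O)CN(c1nc(Cl)nc2[nH]cnc12)C1CC1)C(=O)OCc1ccccc1`, has not yet been measured in this assay. It differs from compound 1 in one place: a group of 4 heavy atoms (4 carbon; no ring) in place of a group of 7 heavy atoms (4 carbon, 3 nitrogen; no ring), on a saturated chain carbon bound to an amide-type nitrogen and a carbonyl carbon. The side chain that leaves carries all of its donors and its one acceptor; the sec-butyl that enters carries none.

Because compound 1 gives 10.2%, the lowest of the three, and the two compounds without that side chain both give higher values, the step from compound 1 to compound 4 is expected to be upward, of moderate size, and probably beyond the scatter; a number 19.8 percentage points higher from compound 1 to compound 4 (beyond the scatter) expresses this expectation. Compound 4 is therefore estimated to reach 30%, with a range from 12% to 55%.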

Compound 4, a percentage reported as activity, at one dose (the size of the read-out at that dose, not a potency): 22%
Beside the measured number, compound 4's estimate is 8 percentage points above it, within the range that was stated.
By their numbers in this assay, from the lowest: compound 1; then compounds 4, 3 and 2 (each within the scatter of the next, the first and the last beyond it).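

In this assay, among the compounds shown here, putting sec-butyl in place of the group of 7 heavy atoms, on a saturated chain carbon bound to an amide-type nitrogen and a carbonyl carbon, gives a number 11.8 percentage points higher from compound 1 to compound 4 (beyond the scatter) as the first single-change step. The step is modest but beyond the scatter, so the number does respond to what this carbon carries. It also shows that the hydrogen-bond donors and the acceptor of the departing group are not needed to reach the higher number at this dose, although this one step cannot separate the loss of those atoms from the change in size or shape, and no measurement here explains the rise.

For the compounds shown here, only this one pair of side chains can be compared, so it stays open whether an amine at the end of a chain, a carboxylic acid, or a longer plain carbon chain on this carbon would give a number closer to that of compound 1 or compound 4. Also open, as far as these compounds go, is whether the same change would give a step of similar size at another dose or time.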